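This account rests on a few compounds, and the source may have more. Where it says the series, first, only, none or still open, it means among the compounds named here.

Measured so far:
compound 1, `COc1cc(/C=C/c2ccc(NC(=O)/C=C/c3ccc(C(F)(F)F)cc3)cc2)cc(OC)c1`: 1780 nM
compound 2, `COc1cc(/C=C/c2ccc(NC(=O)/C=C/c3ccc(F)cc3)cc2)cc(OC)c1`: 11600 nM

Compound 2 gives the higher of the two numbers in a functional assay on HT-29 cells (Homo sapiens) for inhibition, read by MTT assay, with a stated time of 48 h (on this read-out higher numbers stand for weaker inhibition and lower numbers for stronger inhibition), and is tied to compound 1 only through the step of a 6.5-fold higher number from compound 1 to compound 2 (0.81 log units; beyond the scatter). Going by the values given here, that is the single measured step, and it is beyond the scatter.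

Compound 3, `COc1cc(/C=C/c2ccc(NC(=O)/C=C/c3ccc(Br)cc3)cc2)cc(OC)c1`, is not yet measured. It differs from compound 2 by bromo in place of fluoro on an aromatic carbon. Among the compounds with values here, the one measured step bears on it only indirectly: it shows that exchanging the group at this position, from trifluoromethyl to fluoro, moved this assay by a modest amount towards weaker inhibition. A third exchange at the same carbon is therefore expected to move the number again, and the direction expected is back towards the lower number of compound 1, though not fully. Compound 3 is expected to come in at about 3500 nM, within 1200 nM to 10000 nM. The expected step is a 3.3-fold lower number from compound 2 to compound 3 (0.52 log units; beyond the scatter).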

Compound 3, half-maximal inhibitory concentration: 5260 nM
Beside the measured number, compound 3's estimate is 1.5-fold (0.18 log units) below it, within the range that was stated.
By their numbers in this assay, from the lowest: compound 1; then compound 3; then compound 2.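

In this assay, the exchange of fluoro for bromo on this aromatic carbon gives a 2.2-fold lower number from compound 2 to compound 3 (0.34 log units; beyond the scatter), so even a change of one halogen atom for another registers at this position, and the read-out is not tied to the trifluoromethyl group alone. Bromo does not fully match trifluoromethyl, however, with a 3.0-fold higher number from compound 1 to compound 3 (0.47 log units; beyond the scatter), which places the three groups in a clear order with every step beyond the scatter: trifluoromethyl gives the lowest number, bromo an intermediate one and fluoro the highest. Nothing available accounts for this order, so it stands only as an observation.

The compounds shown leave open how chloro, methoxy or an amine on the same carbon would fall relative to these three groups. They also leave open whether the same order would hold if the dimethoxy-substituted side of the shared core were changed.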